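Benzothiazole for thiazole on an inactive amide series

The source may hold more compounds than are shown below. What is called first, only, known or untested is meant among the compounds shown, and "the series" means these compounds.

Measured so far in an assay on L cells for inhibition of Protein-serine O-palmitoleoyltransferase porcupine (Mus musculus), read by reporter gene assay, with a stated time of 24 h; on this read-out lower numbers stand for an effect already at smaller amounts and higher numbers for an effect only at larger amounts of compound:
compound 1, `O=C(CNC(=O)c1nn(-c2ccccc2)c(=O)c2ccccc12)Nc1nccs1`: > 25000 nM
compound 2, `O=C(CSc1nc2c(c(=O)n1-c1ccccc1)SCC2)Nc1ccc(-c2ccoc2)cn1`: 1.5 nM
compound 3, `COc1ccc(-n2c(SCC(=O)Nc3nc4ccc(C(F)(F)F)cc4s3)nc3c(c2=O)SCC3)cc1`: 100 nM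

Compound 1 gives in this assay only a limit of the assay, > 25000 nM, and stands at the limit of > 25000 nM in this assay, at which 1 of the 3 values shown sits. Within the data shown here, compound 2 gives 1.5 nM in this assay and compound 3 gives 100 nM, but both are built on a core unrelated to that of compound 1, so no single-point step connects them to compound 1, and their two values can only be read as showing that amides of this general kind can reach strong potency on this read-out.

Compound 4, `Cc1ccc2nc(NC(=O)CNC(=O)c3nn(-c4ccccc4)c(=O)c4ccccc34)sc2c1`, is not yet measured. It differs from compound 1 in one place: 6-methyl-1,3-benzothiazol-2-yl in place of 1,3-thiazol-2-yl on an amide-type nitrogen. Among the measured compounds shown here, compound 3 carries a related benzothiazolyl amide on its own core, but that core is not the core of compound 1, so it gives no step to lean on here. For the step from compound 1 to compound 4 an improvement is expected, since the starting point is a limit and the change adds the larger ring; the size is estimated as an at least 3.1-fold lower number from compound 1 to compound 4 (0.49 log units; beyond the scatter). For compound 4 the expected value in this assay is 8000 nM, within 1500 nM to 25000 nM, with a fair chance that only a limit is reported again.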

Compound 4, half-maximal effective concentration: 35 nM
The estimate for compound 4 lay 230-fold (2.36 log units) above the measured number; measured number below the stated range.
By their numbers in this assay, from the lowest: compound 2; then compound 4; then compound 3. At a limit, above all of these: compound 1.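

In this assay compound 1 gives > 25000 nM, which is a limit of the assay and not a number: the limit of > 25000 nM in this assay, at which 1 of the 4 values shown sits.

With 6-methyl-1,3-benzothiazol-2-yl in place of 1,3-thiazol-2-yl on an amide-type nitrogen, the series shows an at least 710-fold lower number from compound 1 to compound 4 (2.85 log units; beyond the scatter), and this step is a lower bound on the true change. Among these compounds, compound 2 and compound 3 stand on another core, so only this step shows that the core of compound 1 can give a low number in this assay and that this single position can decide between a limit and a measured value.

The shares of the added six-membered aromatic ring and of the methyl in this step remain unseparated, and an unsubstituted 1,3-benzothiazol-2-yl group would be needed to tell them apart. On these data alone, whether an amine or a carboxylic acid in place of the methyl keeps the effect also stays open.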